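This account rests on a few compounds, and the source may have more. Where it says the series, first, only, none or still open, it means among the compounds named here.

Measured so far in an ADME assay on Vero cells (Chlorocebus sabaeus) for cytotoxicity, with a stated time of 72 h, tested at 10 ug/mL; on this read-out higher numbers stand for a stronger effect at the one concentration tested and lower numbers for a weaker effect:

compound 1, `Cc1ccc(N2CCN/C2=N\N)cc1`: 0%
compound 2, `N=c1c(=O)[nH]nc2n1CCN2c1ccccc1Cl`: 0%
compound 3, `COc1ccc(N2CCn3c2n[nH]c(=O)c3=O)cc1`: 0%

On this read-out compound 1 stands level with compounds 2 and 3 at the digits printed; compound 2 is the nearest, with no change at the digits printed, and compound 3 the furthest, also with no change at the digits printed. All three therefore sit together at the bottom of the scale, within the scatter of one another, and no order among them can be claimed. Within the data shown here, no step between measured compounds is available for this series.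

Compound 4, `N/N=C1\NCCN1c1ccccc1`, has not been measured in this assay. It differs from compound 1 by hydrogen in place of methyl on an aromatic carbon; the methyl leaves and a hydrogen enters. Nothing in the three measured values distinguishes any compound from the others, so no step beyond the scatter is expected for this change. The step of no change at the digits printed from compound 1 to compound 4 (within the scatter) is estimated to be none beyond the scatter. Compound 4 is expected to give 0%, in a range from -5% to 10%.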

Compound 4, a percentage reported as inhibition, at one concentration (the size of the read-out at that concentration, not a potency): 0%
For compound 4 middle estimate and measured number coincide at the digits printed; the range from low to high includes it.
By their numbers in this assay, from the lowest: compounds 1, 2, 3 and 4 (each within the scatter of the next).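

Hydrogen in place of methyl on an aromatic carbon, para to a group of 7 heavy atoms, gives no change at the digits printed from compound 1 to compound 4 (within the scatter) in this assay. Among these compounds, this is the only step that isolates one change, and it shows that the methyl at this position is not required for the read-out to stay where it is at the one concentration tested; with both compounds at the same level, the methyl makes no difference that can be read here. No available measurement bears on this result.

As far as these compounds go, whether an amine, a carboxylic acid or a longer chain at this place would move the read-out remains open. From the compounds shown here alone, since all the values shown stand level, it is also open whether any change to this core can shift the read-out in this assay at all.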